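The compounds below may be only part of what the source reports. "The series", "measured", "known", "first", "only" and "open" are said of these compounds alone.

Measured compounds in an ADME assay on HepG2 cells (Homo sapiens) for cytotoxicity, read by luminescence, CellTiter-Glo and ATP content, with a stated time of 72 h; on this read-out higher numbers stand for an effect only at larger amounts of compound and lower numbers for an effect already at smaller amounts:
- Compound 1 `Fc1ccc(Cc2ccc3c(NCCCNCc4ccco4)ccnc3c2)cc1`: 5600 nM
- Compound 2 `CC(C)CCc1ccc2c(NCCCNCc3ccco3)ccnc2c1`: 11200 nM
- Compound 3 `c1ccc(-c2ccc3c(NCCCNCc4ccco4)ccnc3c2)cc1`: 5920 nM

All three values lie close together. Compound 3 stands nearest to compound 1, with a 1.1-fold higher number from compound 1 to compound 3 (0.02 log units; within the scatter); against compound 2 the comparison is a 1.9-fold lower number from compound 2 to compound 3 (0.28 log units; within the scatter). The remaining step, a 2.0-fold higher number from compound 1 to compound 2 (0.30 log units; within the scatter), is likewise within the scatter. Across these three compounds, swapping the group on the aromatic carbon of the shared core between 4-fluorobenzyl, isopentyl and phenyl has produced no step beyond the scatter in this assay.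

Compound 4 `c1coc(CNCCCNc2ccnc3cc(-c4cccc5ccccc45)ccc23)c1` differs from compound 3 by naphthalen-1-yl in place of phenyl on an aromatic carbon. For the measured compounds named here, the steps that bear on it are the three above, each of them within the scatter; no measured step at this position has moved the number beyond it. On that basis no step beyond the scatter is expected from compound 3 to compound 4, meaning a 1.2-fold lower number from compound 3 to compound 4 (0.07 log units; within the scatter). Compound 4 is estimated at 5000 nM in this assay, with a range from 2000 nM to 12000 nM.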

Compound 4, half-maximal effective concentration: 5600 nM
Beside the measured number, compound 4's estimate is 1.1-fold (0.05 log units) below it, and the stated range covers the measured number.
By their numbers in this assay, from the lowest: compounds 1, 4, 3 and 2 (each within the scatter of the next).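

In this assay, naphthalen-1-yl brings 2 six-membered aromatic rings of carbon only to this aromatic carbon where phenyl brought one, and the number stays within the scatter (a 1.1-fold lower number from compound 3 to compound 4 (0.02 log units; within the scatter)). The same holds against the two groups attached through a saturated carbon (a 2.0-fold lower number from compound 2 to compound 4 (0.30 log units; within the scatter); no change at the digits printed from compound 1 to compound 4 (within the scatter)), so the four compounds now span 6 to 10 heavy atoms in the directly compared phenyl and naphthalen-1-yl groups without a step beyond the scatter. No supporting data bear on why the number stays this flat.

From the compounds shown here alone, whether an amine or a carboxylic acid on this aromatic carbon would move the number beyond the scatter remains open. Also open, going by these compounds, is whether a longer chain in place of isopentyl would stay within it.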